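The source may report more compounds than this note shows. Statements on the series, on what has been measured and on what is new or still open speak of the compounds shown alone.

In a functional assay on MDA-MB-231 cells (Homo sapiens) for antiproliferative activity, read by MTT assay, with a stated time of 72 h (a lower number here means a stronger inhibitor, a higher number a weaker inhibitor), two compounds sharing one core have been measured so far. Compound 1 `NS(=O)(=O)c1ccc(NC(=O)Nc2cccc(-c3nc(-c4ccc(NC(=O)c5cccnc5)cc4Cl)no3)c2)cc1` gives > 10000 nM, which is a limit of the assay and not a number. Going by the values given here, compound 2 `COc1ccc(NC(=O)Nc2cccc(-c3nc(-c4ccc(NC(=O)c5cccnc5)cc4Cl)no3)c2)cc1C(F)(F)F` gives 1700 nM, the only true number available. Among the compounds with values here, the single measured step, an at least 5.8-fold lower number from compound 1 to compound 2 (0.76 log units; beyond the scatter), came from placing 4-methoxy-3-(trifluoromethyl)phenyl in place of 4-sulfamoylphenyl on an amide-type nitrogen. Compound 3 `CS(=O)(=O)Nc1ccc(NC(=O)Nc2cccc(-c3nc(-c4ccc(NC(=O)c5cccnc5)cc4Cl)no3)c2)cc1Cl` changes that same place again, with 3-chloro-4-(methanesulfonamido)phenyl in place of 4-methoxy-3-(trifluoromethyl)phenyl on an amide-type nitrogen. The entering group contains sulfur, as the 4-sulfamoylphenyl group of compound 1 does, so part of the gain in an at least 5.8-fold lower number from compound 1 to compound 2 (0.76 log units; beyond the scatter) is expected to be lost, giving a weaker inhibitor. The estimated change is a 2.6-fold higher number from compound 2 to compound 3 (0.42 log units; beyond the scatter). For compound 3 the estimated value is 4500 nM, within a range from 1500 nM to 13000 nM.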

Compound 3, half-maximal inhibitory concentration: 600 nM
The estimate for compound 3 lay 7.5-fold (0.88 log units) above the measured number; measured number outside the range, below it.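

At this place on the amide-type nitrogen, this assay gives a 2.8-fold lower number from compound 2 to compound 3 (0.45 log units; beyond the scatter), so a sulfur-containing group is not in itself a drawback here, and 3-chloro-4-(methanesulfonamido)phenyl outperforms 4-methoxy-3-(trifluoromethyl)phenyl. The two sulfur-containing groups also differ sharply, with an at least 16-fold lower number from compound 1 to compound 3 (1.22 log units; beyond the scatter), so the weak result of compound 1 belongs to 4-sulfamoylphenyl and not to sulfur-containing groups in general. Compound 1 stands at a limit of the assay and not at a number: the limit of > 10000 nM in this assay, at which 1 of the 3 values shown sits.

Still open, as far as these compounds go, is which part of the entering group carries the gain, the chlorine or the methanesulfonamido group, as the two enter together. A phenyl bearing an amine or a carboxylic acid in place of the methanesulfonamido group, or an ethanesulfonamido group with its longer chain, would show how much change this place accepts.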